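Swapping the Ring on the Pyrazoline Nitrogen of Compound 2

A few compounds are considered here, and "the series" means these few. Any claim that something is new, unique, unknown or untested is made for them only; others in the source may bear on it.

Of the compounds shown here, two sharing a pyrazoline-based core have been measured in a functional assay on HeLa cells (Homo sapiens) for inhibition, read by CCK-8 assay, with a stated time of 48 h; on this read-out lower numbers stand for stronger inhibition and higher numbers for weaker inhibition. Compound 1, `Cc1ccc(C2=NN(C3=NC(c4ccccc4)CS3)C(c3ccc4ccccc4c3)C2)cc1`, gives 2460 nM in this assay. Compound 2, `O=C1CSC(N2N=C(c3ccc(Br)cc3)CC2c2ccc3ccccc3c2)=N1`, gives 4220 nM in this assay. Of the two numbers, compound 2 has the higher one, and its nearest neighbour is compound 1, whose number is lower by a margin that stays within the scatter, so the two values are taken as showing the same strength of inhibition.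

Compound 3, `Brc1ccc(C2=NN(C3=NC(c4ccccc4)CS3)C(c3ccc4ccccc4c3)C2)cc1`, is not yet measured. It differs from compound 2 by a group of 11 heavy atoms (9 carbon, 1 nitrogen, 1 sulfur; one five-membered non-aromatic ring with 2 hetero atoms, one six-membered aromatic ring of carbon only) in place of a group of 6 heavy atoms (3 carbon, 1 nitrogen, 1 oxygen, 1 sulfur; one five-membered non-aromatic ring with 2 hetero atoms), on an amine nitrogen in a ring: the group that enters is the same phenyl-bearing thiazoline carried by compound 1, so compound 3 carries a 4-bromophenyl group where compound 1 carries a methylphenyl group. Since compound 1 and compound 2 stand within the scatter of each other, the step from compound 2 to compound 3 is expected to be small, and the estimated step is a 1.4-fold lower number from compound 2 to compound 3 (0.15 log units; within the scatter), with no direction claimed beyond the scatter. Compound 3 is therefore expected to give about 3000 nM in this assay, with a range from 1200 nM to 7500 nM.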

Compound 3, half-maximal inhibitory concentration: 4960 nM
For compound 3 the middle estimate is 1.7-fold (0.22 log units) below the measured one, and the stated range covers the measured number.
By their numbers in this assay, from the lowest: compounds 1, 2 and 3 (each within the scatter of the next).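

In this assay, the exchange on the amine nitrogen in a ring gives a 1.2-fold higher number from compound 2 to compound 3 (0.07 log units; within the scatter), so at this place the phenyl-bearing thiazoline, with its added six-membered aromatic ring of carbon only, reads the same as the smaller group it replaces, and the gain in heavy atoms brings no change beyond the scatter. Going by these compounds alone, the same compound also gives the first direct reading at the other end of the molecule, where bromo in place of methyl on an aromatic carbon gives a 2.0-fold higher number from compound 1 to compound 3 (0.30 log units; within the scatter), a step printed as within the scatter as well, so neither exchange separates its pair of compounds in this assay. Nothing among the available data gives a reason for these results, and neither step can be tied to any property of the groups involved.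

Within the data shown here, each place has been read for only one exchange, so it remains open whether a group of another kind on the amine nitrogen, such as a simple acetyl group, would move the number beyond the scatter. The same question stands for a carboxylic acid or an amine in place of the bromo on the aromatic ring.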